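The compounds below may be only part of what the source reports. "The series", "measured", "known", "first", "only" and "open" are said of these compounds alone.

Working notes on the series: compound 1 `CCCCN1C(=O)[C@@H](C)NC(=O)[C@@H]2Cc3ccc(OC)c(c3)Oc3ccc(cc3)C[C@@H](C(=O)N2C)N(C)C(=O)[C@H](C)NC(=O)[C@H](Cc2ccc(OC)cc2)N(C)C(=O)[C@@H]1C` and compound 2 `CCCCCN1C(=O)[C@@H](C)NC(=O)[C@@H]2Cc3ccc(OC)c(c3)Oc3ccc(cc3)C[C@@H](C(=O)N2C)N(C)C(=O)[C@H](C)NC(=O)[C@H](Cc2ccc(OC)cc2)N(C)C(=O)[C@@H]1C` share one core and differ only in the chain on an amide-type nitrogen in a ring. In a functional assay on P388 cells (Mus musculus) for cytotoxicity (on this read-out lower numbers stand for stronger inhibition and higher numbers for weaker inhibition), compound 1 gives 12 nM and compound 2 gives 21.4 nM. Only these two numbers exist so far, and compound 2 stands within the scatter of compound 1. Compound 3 `C=C(C)CN1C(=O)[C@@H](C)NC(=O)[C@@H]2Cc3ccc(OC)c(c3)Oc3ccc(cc3)C[C@@H](C(=O)N2C)N(C)C(=O)[C@H](C)NC(=O)[C@H](Cc2ccc(OC)cc2)N(C)C(=O)[C@@H]1C` carries 1-methylethenyl in place of butyl on a saturated chain carbon bound to an amide-type nitrogen in a ring. Among the measured compounds shown here, one measured step bears on this change: a 1.8-fold higher number from compound 1 to compound 2 (0.25 log units; within the scatter), for methyl in place of hydrogen on the same chain, and it stays within the scatter. For the measured compounds named here, no measured compound has a double bond in this chain, so that part of the change is untested. No step beyond the scatter is therefore expected in this assay, and no direction can be assigned with confidence. The expected step is a 1.4-fold lower number from compound 2 to compound 3 (0.15 log units; within the scatter). For compound 3 the estimated value is 15 nM, with an expected range of 6 nM to 45 nM.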

Compound 3, half-maximal inhibitory concentration: 11 nM
Beside the measured number, compound 3's estimate is 1.4-fold (0.13 log units) above it; the measured number falls inside the stated range.
By their numbers in this assay, from the lowest: compounds 3, 1 and 2 (each within the scatter of the next).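

In this assay the first double bond in this chain gives a 1.9-fold lower number from compound 2 to compound 3 (0.29 log units; within the scatter), and the same change read against the shorter saturated chain gives a 1.1-fold lower number from compound 1 to compound 3 (0.04 log units; within the scatter), so this position now holds three chains whose numbers all lie within the scatter of one another. The earlier pair showed this only for a difference of one methyl between saturated chains, whereas compound 3 extends it to a chain that is both branched and unsaturated, with 1-methylethenyl in place of butyl on a saturated chain carbon bound to an amide-type nitrogen in a ring. Nothing available explains why these chains read alike, and no measurement outside this read-out bears on the result.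

The branch and the double bond enter together in compound 3, so their separate contributions stay unresolved, and an unbranched chain ending in a double bond or a branched saturated chain such as 2-methylpropyl would be needed to separate them. From the compounds shown here alone, it also remains open whether this position would accept an amine, a carboxylic acid, a benzyl group or a chain longer than pentyl with the number still in the same range.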